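This account rests on a few compounds, and the source may have more. Where it says the series, first, only, none or still open, it means among the compounds named here.

Compound 1 `CCC#C[C@@]1(O)[C@@H](CO)O[C@@H](n2ccc(N)nc2=O)[C@@H]1O` gives 108000 nM in a functional assay on KB cells (Homo sapiens), read by MTT assay (a lower number here means a stronger inhibitor, a higher number a weaker inhibitor), and compound 2 `C=C[C@@]1(O)[C@@H](CO)O[C@@H](n2ccc(N)nc2=O)[C@@H]1O` gives 74300 nM in this assay. The step of a 1.5-fold lower number from compound 1 to compound 2 (0.16 log units; within the scatter) comes from the change (vinyl in place of but-1-yn-1-yl on a saturated ring carbon). Compound 3 `CCC#C[C@@]1(O)[C@@H](CO)O[C@@H](n2ccc(=O)[nH]c2=O)[C@@H]1O` gives 226000 nM in this assay; the difference between its core and that of compound 1 is not broken down here. Compound 4 `C=C[C@@]1(O)[C@@H](CO)O[C@@H](n2ccc(=O)[nH]c2=O)[C@@H]1O` carries the same change, (vinyl in place of but-1-yn-1-yl on a saturated ring carbon), on the core of compound 3, at a place described in the same words as before. From compound 3 the step is expected to be a 1.5-fold lower number from compound 3 to compound 4 (0.18 log units; within the scatter), resting on the earlier step of a 1.5-fold lower number from compound 1 to compound 2 (0.16 log units; within the scatter), which stayed within the scatter. On that basis compound 4 is estimated at 150000 nM in this assay, with an expected range from 70000 nM to 350000 nM.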

Compound 4, half-maximal inhibitory concentration: 51800 nM
The estimate for compound 4 lay 2.9-fold (0.46 log units) above the measured number; the measured number lies below the stated range.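

In this assay, vinyl in place of but-1-yn-1-yl on a saturated ring carbon gives a 4.4-fold lower number from compound 3 to compound 4 (0.64 log units; beyond the scatter), a step beyond the scatter on this core. Within the data shown here, the same change does not carry over at the same size from one core to the other: the same change on two cores in this assay, a 1.5-fold lower number (0.16 log units; within the scatter) from compound 1 to compound 2 and a 4.4-fold lower number (0.64 log units; beyond the scatter) from compound 3 to compound 4, 3.0-fold (0.48 log units) apart, beyond the scatter of two such steps This shows that, in this series, a step read on one core cannot be assumed to hold on the other, but with only two pairs it does not show which feature of the cores sets the gap or how the change would behave on any further core.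

The compounds shown leave open how an ethyl group, a longer alkyl chain or an amine on that saturated ring carbon would read in this assay. They also leave open whether the gap between the two cores would persist with such groups.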